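The compounds below may be only part of what the source reports. "The series", "measured", "known", "first", "only" and "open" are said of these compounds alone.

Compound 1 `CC1=CCC[C@](C)(CC/C(C)=C/CC2=C(O)C(=O)C=C(N[C@@H](C(=O)O)[C@@H](C)O)C2=O)[C@@H]1C` is one of two measured members of this set. In an ADME assay on L1210 cells (Mus musculus) for cytotoxicity, with a stated time of 48 h (a higher number here means a weaker inhibitor, a lower number a stronger inhibitor), compound 1 gives only a limit, > 10 ug/mL. Compound 2 `C=C1[C@H](C)CCC[C@]1(C)CC/C(C)=C/CC1=C(O)C(=O)C=C(N[C@@H](C(=O)O)[C@@H](C)O)C1=O` differs from it in the sesquiterpene part alone. In this assay compound 2 likewise returns a limit, > 10 ug/mL. Within the data shown here, the single measured step, a step that the two limits leave unreadable from compound 1 to compound 2, therefore carries no readable size, and both results sit at the limit of > 10 ug/mL in this assay, at which 2 of the 2 values shown sit.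

Compound 3 `COC1=CC(=O)C(O)=C(C/C=C(\C)CC[C@@]2(C)CCC=C(C)[C@H]2C)C1=O` has not yet been tested. Relative to compound 1 the change is methoxy in place of (1-carboxy-2-hydroxypropyl)amino on a double-bonded ring carbon. Among the measured compounds shown here, no measured step touches this part of the core, so nothing in the data sets a direction or size for it, and the two limits only say that compound 1 is no stronger than the assay's ceiling. Compound 3 is therefore expected to lie somewhere below or near that ceiling, 3 ug/mL, between 1 ug/mL and 10 ug/mL, the step of an at least 3.3-fold lower number from compound 1 to compound 3 (0.52 log units; beyond the scatter) being an estimate without support from the measured pair.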

Compound 3, half-maximal inhibitory concentration: 2 ug/mL
Estimate against measurement, compound 3: 1.5-fold (0.18 log units) above, within the range that was stated.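

Among these compounds, replacing (1-carboxy-2-hydroxypropyl)amino with methoxy on the double-bonded ring carbon gives the first readable step in this assay, an at least 5.0-fold lower number from compound 1 to compound 3 (0.69 log units; beyond the scatter). Among the compounds shown here, the step between compound 1 and compound 2, which changes only the sesquiterpene part, cannot be read, so this is the first sign that the read-out can respond to a structural change, and it does so at this position of the core. Only a bound on the size of the new step can be given, because its starting value is a limit: the limit of > 10 ug/mL in this assay, at which 2 of the 3 values shown sit.

The swap removes the whole amino acid group at once, so the compounds shown do not tell which of its parts matters. On these data alone, how a plain amino group, an ethoxy group or a longer alkoxy chain at this position would compare remains open, as does whether the sesquiterpene part of compound 2 would read differently alongside methoxy.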